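This account rests on a few compounds, and the source may have more. Where it says the series, first, only, none or still open, it means among the compounds named here.

Compound 3 `COC(=O)C(Nc1cc(NS(=O)(=O)/C=C/c2c(OC)cc(OC)cc2OC)ccc1OC)c1ccc(Cl)cc1` stands highest of the three numbers in a functional assay on DU-145 cells (Homo sapiens) for cytotoxicity, read by trypan blue exclusion, with a stated time of 96 h; a higher number here means a weaker inhibitor, a lower number a stronger inhibitor. Compound 1 `COc1cc(OC)c(/C=C/S(=O)(=O)Nc2ccc(OC)c(O)c2)c(OC)c1` gives 30 nM in this assay, compound 2 `COC(=O)CNc1cc(NS(=O)(=O)/C=C/c2c(OC)cc(OC)cc2OC)ccc1OC` gives 350 nM, and compound 3 gives 5000 nM. The two measured steps were both large: there was a 12-fold higher number from compound 1 to compound 2 (1.07 log units; beyond the scatter) and then a 14-fold higher number from compound 2 to compound 3 (1.15 log units; beyond the scatter).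

Compound 4 `COc1cc(OC)c(/C=C/S(=O)(=O)Nc2ccc(OC)c(NC(C(=O)O)c3ccc(Cl)cc3)c2)c(OC)c1` differs from compound 3 by hydrogen in place of methyl on an oxygen next to a carbonyl group. Within the data shown here, neither measured step bears directly on this change, since one introduced the ((methoxycarbonyl)methyl)amino group and the other the 4-chlorophenyl group, and no pair in the set differs by the methyl ester becoming the acid. The expectation therefore rests on little more than the position of compound 3 itself. With a carboxy in place of methoxycarbonyl, a modest weakening is expected, so the step is estimated as a 2.0-fold higher number from compound 3 to compound 4 (0.30 log units; within the scatter). Compound 4 is accordingly expected to give about 10000 nM in this assay, with a likely range from 3000 nM to 40000 nM.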

Compound 4, half-maximal inhibitory concentration: 75 nM
Estimate against measurement, compound 4: 130-fold (2.12 log units) above; measured number outside the range, below it.
By their numbers in this assay, from the lowest: compound 1; then compound 4; then compound 2; then compound 3.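

In this assay, among these compounds, hydrogen in place of methyl on an oxygen next to a carbonyl group gives a 67-fold lower number from compound 3 to compound 4 (1.82 log units; beyond the scatter) and so shows what no earlier pair could: at this site, methoxycarbonyl and carboxy are far apart. Carboxy(4-chlorophenyl)methyl in place of (methoxycarbonyl)methyl on a nitrogen on an aromatic ring gives a 4.7-fold lower number from compound 2 to compound 4 (0.67 log units; beyond the scatter) here, while (carboxy(4-chlorophenyl)methyl)amino in place of hydroxy on an aromatic carbon gives a 2.5-fold higher number from compound 1 to compound 4 (0.40 log units; beyond the scatter) and so remains short of the hydroxy compound. Nothing measured here accounts for the size of the ester-to-acid change.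

Going by these compounds, it remains open whether the same exchange would move the (methoxycarbonyl)methyl group of compound 2 as far. Also open, on these data alone, is what a primary amide in place of the carboxy group, or a longer chain carrying it, would give.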